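Sulfonamide Piperidine Series: Cytotoxicity Limits and a Methoxyphenyl Variant

The source may hold more compounds than are shown below. What is called first, only, known or untested is meant among the compounds shown, and "the series" means these compounds.

Compound 1, `CC1CCN(C2CCN(S(=O)(=O)c3cn(C)cn3)CC2)CC1`, in an ADME assay on HCT-116 cells (Homo sapiens) for cytotoxicity, read by CellTiter-Glo, with a stated time of 72 h (on this read-out higher numbers stand for weaker inhibition and lower numbers for stronger inhibition), gives > 10000 nM, which is a limit of the assay and not a number.
Compound 2, `Cc1ccc(S(=O)(=O)N2CCC(N3CCC(C)CC3)CC2)cc1C`, in this assay gives > 5000 nM, likewise a limit.
Compound 3, `CC1CCN(C2CCN(S(=O)(=O)c3ccc(C#N)cc3)CC2)CC1`, in this assay gives > 5000 nM, again a limit.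

Compound 3 therefore stands at a limit, as do the two other values in this set; none of the three is a measured number. The steps a step that the two limits leave unreadable from compound 1 to compound 2, a step that the two limits leave unreadable from compound 1 to compound 3 and a step that the two limits leave unreadable from compound 2 to compound 3 cannot be sized because the limit of > 10000 nM in this assay, at which 1 of the 3 values shown sits, and the limit of > 5000 nM in this assay, at which 2 of the 3 values shown sit, leave every comparison open. What the three exchanges on the sulfonyl sulfur do show is that none of them brought a compound to a readable potency in this assay.

Compound 4, `COc1cccc(S(=O)(=O)N2CCC(N3CCC(C)CC3)CC2)c1`, differs from compound 3 by 3-methoxyphenyl in place of 4-cyanophenyl on a sulfonyl sulfur. All three measured steps bear on this change in kind, as exchanges of the group on the sulfonyl sulfur, but each is unreadable, so no direction and no size can be drawn from them. The step from compound 3 to compound 4 is therefore expected to be a step that the limit leaves unreadable from compound 3 to compound 4, nothing beyond the scatter that could be resolved against a limit. Compound 4 is estimated at 9000 nM, with a range from 3000 nM to 30000 nM, and it is expected that this assay will most likely again report only a limit.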

Compound 4, half-maximal inhibitory concentration: > 5000 nM
Compound 4 was reported as a limit (the forecaster's own chance of this, stated with the estimate: 85%); the middle value is on the limit's open side.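

Compound 4 adds no readable step: its comparisons with compound 1, compound 2 and compound 3 all rest on limits in this assay and none can be sized. The compounds shown leave open whether any exchange on the sulfonyl sulfur changes potency in this assay at all, and how far each compound lies past its limit.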